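A few compounds are considered here, and "the series" means these few. Any claim that something is new, unique, unknown or untested is made for them only; others in the source may bear on it.

Compound 3 `CC(=O)NS(=O)(=O)c1ccc(-n2nc(-c3ccccc3)cc2-c2cc(O)ccc2O)cc1` carries a 2,5-dihydroxyphenyl group on an aromatic carbon of a five-membered aromatic ring with 2 nitrogen. In a functional assay on cells (Cancer cell lines, Homo sapiens) for cytotoxicity, read by sulforhodamine B assay, with a stated time of 48 h (a higher number here means a weaker inhibitor of growth, a lower number a stronger inhibitor of growth), compound 3 gives 100000 nM, the highest of the three numbers measured. Compound 2 `NS(=O)(=O)c1ccc(-n2nc(-c3ccccc3)cc2-c2cc(O)ccc2O)cc1` gives 77600 nM, and compound 1 `COc1ccc(OC)c(-c2cc(-c3ccccc3)nn2-c2ccc(S(=O)(=O)NC(C)=O)cc2)c1` gives 12000 nM. Compound 4 `CC(=O)NS(=O)(=O)c1ccc(-n2nc(-c3ccccc3)cc2C2=CC(=O)C=CC2=O)cc1` differs from compound 3 by a group of 8 heavy atoms (6 carbon, 2 oxygen; one six-membered non-aromatic ring of carbon only) in place of a group of 8 heavy atoms (6 carbon, 2 oxygen; one six-membered aromatic ring of carbon only), on an aromatic carbon. Among the measured compounds shown here, two measured steps bear on the comparison: an 8.3-fold higher number from compound 1 to compound 3 (0.92 log units; beyond the scatter), and a 1.3-fold higher number from compound 2 to compound 3 (0.11 log units; within the scatter). The first shows that exchanging the ring at this carbon can move the number substantially. Compound 4 is therefore expected to show a 3.3-fold lower number from compound 3 to compound 4 (0.52 log units; beyond the scatter), moving toward the number of compound 1 at 12000 nM. Compound 4 is estimated at 30000 nM, with a range from 8000 nM to 100000 nM.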

Compound 4, concentration for 50% growth inhibition: 100000 nM
For compound 4 the middle estimate is 3.3-fold (0.52 log units) below the measured one; the range from low to high includes it.
By their numbers in this assay, from the lowest: compound 1; then compounds 2, 3 and 4 (each within the scatter of the next).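

In this assay, replacing the 2,5-dihydroxyphenyl group with the non-aromatic six-membered carbon ring, which has no hydrogen-bond donors, gives no change at the digits printed from compound 3 to compound 4 (within the scatter) and so does not separate the two groups. Among the compounds shown here, the step of an 8.3-fold higher number from compound 1 to compound 4 (0.92 log units; beyond the scatter) leaves the 2,5-dimethoxyphenyl group of compound 1 as the only group here with a number set apart from the others. Nothing measured here gives a reason for these numbers.

On these data alone, whether a single methoxy group would keep the number of compound 1 remains open. So does the outcome of placing an amine or a carboxylic acid on this phenyl ring.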